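The source may hold more compounds than are shown below. What is called first, only, known or untested is meant among the compounds shown, and "the series" means these compounds.

Of the compounds shown here, two with a shared core have been measured so far in an ADME assay on the whole organism (Mus musculus, strain CD-1) for pharmacokinetics; on this read-out lower numbers stand for slow clearance and higher numbers for fast clearance. Compound 1 `COc1cc([C@](O)(CCN(C)C)[C@@H](c2cc3cc(C#N)ccc3nc2OC)c2cccc(OC)c2F)cc(SC)n1` gives 42 mL/min/kg, while compound 2 `COc1cccc([C@H](c2cc3cc(Br)ccc3nc2OC)[C@@](O)(CCN(C)C)c2cc(SC)nc(SC)c2)c1F` gives 13 mL/min/kg. Compound 2 therefore holds the lower of the two numbers, and the gap between them lies beyond the usual scatter of repeated measurements.

Compound 3 `COc1cccc([C@H](c2cc3cc(C#N)ccc3nc2OC)[C@@](O)(CCN(C)C)c2cc(SC)nc(SC)c2)c1F` departs from compound 2 at one place: cyano in place of bromo on an aromatic carbon. For the measured compounds named here, no measured pair shows this swap on its own, so the expectation rests on little evidence. Going by the values given here, the only cyano-bearing compound measured is compound 1 at 42 mL/min/kg, and it also differs from compound 3 elsewhere on the structure. That value points to a modest upward step in this assay, one that may not clear the scatter by much. The estimate amounts to an expected 1.7-fold higher number from compound 2 to compound 3 (0.23 log units; within the scatter). For compound 3 the expected clearance is 22 mL/min/kg, with an estimated range of 11 mL/min/kg to 42 mL/min/kg.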

Compound 3, clearance: 44 mL/min/kg
Compound 3: middle estimate off by 2.0-fold (0.30 log units), on the low side, outside the stated range (above it).
By their numbers in this assay, from the lowest: compound 2; then compounds 1 and 3 (each within the scatter of the next).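

In this assay, putting cyano in place of bromo on this aromatic carbon, which lies on the carbon-only ring of the fused system, gives a 3.4-fold higher number from compound 2 to compound 3 (0.53 log units; beyond the scatter) and so shows that a single change at this position can move clearance beyond the scatter. The other pair, with methylsulfanyl in place of methoxy on an aromatic carbon elsewhere on the structure, gives a 1.0-fold higher number from compound 1 to compound 3 (0.02 log units; within the scatter); this step stays within the scatter, so with cyano present that swap has no readable effect on the number. Nothing available explains either result.

On these data alone, whether other groups at this position, such as chloro, methyl or an amine, would give numbers closer to compound 2 or to compound 3 remains open. For the compounds shown here, it is also open whether methylsulfanyl and methoxy would still give numbers within the scatter of each other with bromo on the fused system, as the only pair showing that swap carries cyano.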